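One carbon shorter on the amide chain

A few compounds are considered here, and "the series" means these few. Any claim that something is new, unique, unknown or untested is made for them only; others in the source may bear on it.

Compound 1 `CC(C)CCC(=O)Nc1ccn([C@H]2CC[C@H](O[C@H]3O[C@H](C)[C@@H](N(C)C)[C@H](O)[C@H]3O)[C@@H](C)O2)c(=O)n1` carries an isopentylcarbonyl amide on the shared core together with a dimethylamino-bearing sugar. Among the compounds with values here, in a functional assay on HCT-116 cells (Homo sapiens) for cytotoxicity, read by sulforhodamine B assay, with a stated time of 24 h (on this read-out higher numbers stand for weaker inhibition and lower numbers for stronger inhibition), compound 1 gives 390 nM, the only number that this set of measurements returns. Compound 2 `CC(C)=CC(=O)Nc1ccn([C@H]2C[C@@H](O)[C@H](O)[C@@H](C)O2)c(=O)n1` carries a different amide chain and a different sugar; in this assay compound 2 reaches only the limit of the assay, > 20000 nM. Compound 3 `C[C@H]1O[C@@H](n2ccc(NC(=O)CC(C)(C)O)nc2=O)CC[C@@H]1O` carries yet another amide chain on a simpler sugar; in this assay compound 3 likewise reaches only the limit, > 20000 nM. Thus the limit of > 20000 nM in this assay, at which 2 of the 3 values shown sit, frames the set, and compound 1 stands alone as the one measured number. No pair among these three compounds differs in a single place, so no measured step exists from which the weight of a single change could be read.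

Compound 4 `CC(C)CC(=O)Nc1ccn([C@H]2CC[C@H](O[C@H]3O[C@H](C)[C@@H](N(C)C)[C@H](O)[C@H]3O)[C@@H](C)O2)c(=O)n1` keeps the sugar and core of compound 1 and differs only in the amide chain: isopropyl in place of isobutyl on a saturated chain carbon bound to a carbonyl carbon. Taking the same difference one bond further out, isopentylcarbonyl becomes isobutylcarbonyl. A shorter chain of this kind is a small change, and the step from compound 1 to compound 4 is expected to be modest, a 1.5-fold higher number from compound 1 to compound 4 (0.19 log units; within the scatter), leaning toward weaker inhibition but not clearly beyond the scatter. Compound 4 is accordingly estimated at 600 nM, with a likely range from 150 nM to 2500 nM.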

Compound 4, half-maximal inhibitory concentration: 2140 nM
Compound 4: middle estimate off by 3.6-fold (0.55 log units), on the low side, within the range that was stated.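

With the sugar and the shared core held fixed, the amide chain proves to be a position that matters in this assay: isopropyl in place of isobutyl on a saturated chain carbon bound to a carbonyl carbon gives a 5.5-fold higher number from compound 1 to compound 4 (0.74 log units; beyond the scatter). Within the data shown here, this is the first step in the set that can be read, and it shows that going from isopentylcarbonyl to isobutylcarbonyl is enough to move the read-out beyond the scatter, toward weaker inhibition. Even so, compound 4 still gives a measured number and does not sit at the limit of the assay that frames this set: the limit of > 20000 nM in this assay, at which 2 of the 4 values shown sit.

One step gives a direction for this pair only, and whether a longer chain than isopentylcarbonyl, or an amine or a carboxylic acid on the amide chain, would continue or reverse it stays open, as none of these is among the compounds shown. Compound 2 and compound 3 each differ from compound 1 and compound 4 in more than one place, so any steps to them cannot be read, and the share of the amide chain and of the sugar in their limit values remains unresolved.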